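Replacing phenyl with cyclopropyl: working notes

The compounds below may be only part of what the source reports. "The series", "measured", "known", "first", "only" and "open" are said of these compounds alone.

In a functional assay (mast cells) for inhibition, with Rattus norvegicus as the target (a higher number here means that more compound is needed for the effect, a lower number that less compound is needed), the values so far are:
Compound 1 (`CC1CC/C(=N\Nc2ccc(C(F)(F)F)cc2)c2ncc(C(=O)O)c(=O)n21`): 280 nM
Compound 2 (`CC1CC/C(=N\Nc2ccc(C(=O)O)cc2)c2ncc(C(=O)O)c(=O)n21`): 1000000 nM
Compound 3 (`CC1CC/C(=N\Nc2ccc(-c3ccccc3)cc2)c2ncc(C(=O)O)c(=O)n21`): 4400 nM

Compound 3 gives 4400 nM and stands in the middle of the three, with compound 1 lower and compound 2 higher. Next is compound 4 (`CC1CC/C(=N\Nc2ccc(C3CC3)cc2)c2ncc(C(=O)O)c(=O)n21`), with cyclopropyl in place of phenyl on an aromatic carbon as the change: cyclopropyl in place of phenyl on an aromatic carbon, para to a large group. The large steps of a 16-fold higher number from compound 1 to compound 3 (1.20 log units; beyond the scatter) and a 230-fold lower number from compound 2 to compound 3 (2.36 log units; beyond the scatter) bear on it, both at the same place, while a 3600-fold higher number from compound 1 to compound 2 (3.55 log units; beyond the scatter) marks the full span. Cyclopropyl itself is untested here. Trifluoromethyl gave way to phenyl with a rise in a 16-fold higher number from compound 1 to compound 3 (1.20 log units; beyond the scatter) and cyclopropyl is expected to recover part of that rise. Expected in this assay is a 4.0-fold lower number from compound 3 to compound 4 (0.60 log units; beyond the scatter) as the estimated step, moderate in size. For compound 4 the estimated value is 1100 nM with an expected range from 300 nM to 4000 nM in this series.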

Compound 4, half-maximal effective concentration: 1000 nM
Compound 4: the middle estimate sits 1.1-fold (0.04 log units) above what was measured; the range from low to high includes it.
By their numbers in this assay, from the lowest: compound 1; then compound 4; then compound 3; then compound 2.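

Replacing phenyl (6 heavy atoms) with cyclopropyl (3 heavy atoms) on this aromatic carbon, para to a large group, lowers the number (a 4.4-fold lower number from compound 3 to compound 4 (0.64 log units; beyond the scatter)), so an aromatic ring is not required here. Cyclopropyl does not match trifluoromethyl (a 3.6-fold higher number from compound 1 to compound 4 (0.55 log units; beyond the scatter)), yet it stands far from carboxy (a 1000-fold lower number from compound 2 to compound 4 (3.00 log units; beyond the scatter)), placing it within the span set by the earlier compounds. No measurement here accounts for this order.

The compounds shown leave open how an amine, a fluorine atom or a longer alkyl chain would compare at this place.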